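A few compounds are considered here, and "the series" means these few. Any claim that something is new, unique, unknown or untested is made for them only; others in the source may bear on it.

Working notes on the series, para substituent on the aryl ring of the shared core. In a functional assay on KBVIN cells (Homo sapiens) for antiproliferative activity, read by sulforhodamine B assay, with a stated time of 3 days (a lower number here means that less compound is needed, a higher number that more compound is needed for the effect), compound 3 `CCOc1ccc(-c2cc(=O)c3c(o2)C(CC)(CC)C(=O)C(CC)=C3O)cc1` has the highest number of the three measured compounds at 7.54 uM, ahead of compound 2 `CCC1=C(O)c2c(oc(-c3ccc(OC)cc3)cc2=O)C(CC)(CC)C1=O` at 0.68 uM and compound 1 `CCC1=C(O)c2c(oc(-c3ccc(C)cc3)cc2=O)C(CC)(CC)C1=O` at 0.08 uM.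

The next compound, compound 4 `CCC1=C(O)c2c(oc(-c3ccc(F)cc3)cc2=O)C(CC)(CC)C1=O`, carries fluoro in place of ethoxy on an aromatic carbon, para to a large group (fluoro in place of ethoxy on an aromatic carbon). Among the compounds with values here, no fluoro compound has been measured, so the comparison rests on the three other substituents. The modest 8.5-fold higher number from compound 1 to compound 2 (0.93 log units; beyond the scatter) covers methoxy in place of methyl. The large 11-fold higher number from compound 2 to compound 3 (1.04 log units; beyond the scatter) and the large 94-fold higher number from compound 1 to compound 3 (1.97 log units; beyond the scatter) are the two steps that reach the ethoxy compound, and both bear directly on removing ethoxy. Across these three compounds the number rises from methyl through methoxy to ethoxy, and none goes against that order, although three compounds make only a short series.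

Leaving ethoxy has so far always meant a lower number, so a large step downward in this assay is expected here. The expected step is a 25-fold lower number from compound 3 to compound 4 (1.40 log units; beyond the scatter). For compound 4 the estimated value is 0.3 uM, with an expected range of 0.06 uM to 1.5 uM.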

Compound 4, concentration for half-maximal effect: 1.85 uM
The estimate for compound 4 lay 6.2-fold (0.79 log units) below the measured number; measured number outside the range, above it.
By their numbers in this assay, from the lowest: compound 1; then compound 2; then compound 4; then compound 3.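

Working notes, continued. In this assay the change to fluoro gives a 4.1-fold lower number from compound 3 to compound 4 (0.61 log units; beyond the scatter), so removing ethoxy again lowers the number, but much less than the step to methyl does, and compound 4 does not pass the methoxy compound, with a 2.7-fold higher number from compound 2 to compound 4 (0.43 log units; beyond the scatter). The step of a 23-fold higher number from compound 1 to compound 4 (1.36 log units; beyond the scatter) shows that, at this place para to a large group, removing ethoxy does not by itself bring the number down to that of compound 1: the outcome depends on which group enters, and methyl remains clearly ahead of the other three groups. The order now runs methyl, methoxy, fluoro, ethoxy, and with fluoro, at 1 heavy atom, falling behind methoxy, compound 4 goes against any reading of this order as a simple rise with group size; nothing at hand accounts for the order of these four groups.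

The compounds shown leave open whether the low number of compound 1 is particular to methyl or extends to ethyl, chloro or trifluoromethyl at this place. They also leave open how an amine or a longer chain such as propoxy would stand against ethoxy.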